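The source may report more compounds than this note shows. Statements on the series, on what has been measured and on what is new or still open speak of the compounds shown alone.

The measured compounds:
compound 1, `NC1=C(C(=O)c2ccccc2)C(c2ccc(Br)cc2)N(CCCn2ccnc2)C1=O`: 169000 nM
compound 2, `Cc1ccc(NC2=C(C(=O)c3ccccc3)C(c3ccc(Br)cc3)N(CCCn3ccnc3)C2=O)cc1`: 25800 nM

Within the data shown here, in a functional assay on NCI-H1299 cells (Homo sapiens) for antiproliferative activity, read by MTT assay, with a stated time of 72 h (on this read-out lower numbers stand for stronger inhibition and higher numbers for weaker inhibition), compound 2 gives 25800 nM, the lowest of the two numbers; its only neighbour is compound 1, which gives 169000 nM. Among the measured compounds shown here, the one measured step is a 6.6-fold lower number from compound 1 to compound 2 (0.82 log units; beyond the scatter), a change at the amine nitrogen. Compound 3, `O=C(C1=C(Nc2ccc(Br)cc2)C(=O)N(CCCn2ccnc2)C1c1ccc(Br)cc1)c1ccccc1`, differs from compound 2 by bromo in place of methyl on an aromatic carbon. For the measured compounds named here, no measured step touches a substituent on that aryl ring: the step from compound 1 to compound 2 reports only the presence of the aryl group and gives no guide to exchanging the group on it. The expected step is therefore a 1.3-fold lower number from compound 2 to compound 3 (0.11 log units; within the scatter), within the scatter or little beyond it, in no firm direction. The estimate for compound 3 is 20000 nM, with a range from 7000 nM to 60000 nM.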

Compound 3, half-maximal inhibitory concentration: 19300 nM
For compound 3 the middle estimate is 1.0-fold (0.02 log units) above the measured one; measured number inside the range.
By their numbers in this assay, from the lowest: compounds 3 and 2 (each within the scatter of the next); then compound 1.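

In this assay, among these compounds, the first exchange on the aryl ring gives a 1.3-fold lower number from compound 2 to compound 3 (0.13 log units; within the scatter), so bromo in place of methyl, para to a large group, does not separate these two analogues. With 4-bromophenyl in place of hydrogen on the amine nitrogen, the result is an 8.8-fold lower number from compound 1 to compound 3 (0.94 log units; beyond the scatter), which is beyond the scatter, as is a 6.6-fold lower number from compound 1 to compound 2 (0.82 log units; beyond the scatter) with 4-methylphenyl, so the change from hydrogen holds with both aryl groups. Nothing available explains either result.

As far as these compounds go, it remains open whether a methoxy group, a carboxylic acid or an amine at this ring position would move the number beyond the scatter. Also open, from the compounds shown here alone, is whether a benzyl group or a plain ethyl chain on the amine nitrogen would serve as these aryl groups do.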